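Replacing 4-cyanophenyl on compound 3 with 3-ethylphenyl

A few compounds are considered here, and "the series" means these few. Any claim that something is new, unique, unknown or untested is made for them only; others in the source may bear on it.

Within the data shown here, in a physicochemical assay for solubility, read by spectrophotometry, in phosphate buffer, with a stated time of 18 h, at pH 7.4 (on this read-out lower numbers stand for lower solubility and higher numbers for higher solubility), compound 3 `Cc1nn(-c2ccccc2)c2nc(-c3ccc(C#N)cc3)c(C#N)c(-c3ccccc3O)c12` gives 1700 nM, the lowest of the three numbers measured so far. Compound 1 `Cc1ccc(-c2nc3c(c(C)nn3-c3ccccc3)c(-c3ccccc3O)c2C#N)cc1` gives 26000 nM, and compound 2 `Cc1ccccc1-c1nc2c(c(C)nn2-c2ccccc2)c(-c2ccccc2O)c1C#N` gives 21000 nM. Compound 4 `CCc1cccc(-c2nc3c(c(C)nn3-c3ccccc3)c(-c3ccccc3O)c2C#N)c1` keeps the shared core but carries 3-ethylphenyl in place of 4-cyanophenyl on an aromatic carbon.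

Two large steps bear most directly on this change: a 15-fold lower number from compound 1 to compound 3 (1.18 log units; beyond the scatter) and a 12-fold lower number from compound 2 to compound 3 (1.09 log units; beyond the scatter). In both, a methylphenyl group gives way to 4-cyanophenyl. Compound 4 reverses that kind of change, since its phenyl group again carries a carbon chain and no cyano group. The third step, a 1.2-fold lower number from compound 1 to compound 2 (0.09 log units; within the scatter), suggests that the place of the methyl mattered little between those two compounds. Among the measured compounds shown here, no measured compound carries 3-ethylphenyl, so this comparison remains indirect.

A large rise is therefore expected, estimated as a 9.4-fold higher number from compound 3 to compound 4 (0.97 log units; beyond the scatter). Compound 4 is expected to read about 16000 nM, within an estimated range of 6000 nM to 38000 nM.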

Compound 4, solubility: 11000 nM
The estimate for compound 4 lay 1.5-fold (0.16 log units) above the measured number; measured number inside the range.
By their numbers in this assay, from the lowest: compound 3; then compounds 4, 2 and 1 (each within the scatter of the next, the first and the last beyond it).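

With 3-ethylphenyl, a third phenyl group carrying a carbon chain now stands at this position in this assay, and it too sits well clear of 4-cyanophenyl, giving a 6.5-fold higher number from compound 3 to compound 4 (0.81 log units; beyond the scatter). Against the two methylphenyl groups the differences are smaller: there is a 1.9-fold lower number from compound 2 to compound 4 (0.28 log units; within the scatter) and also a 2.4-fold lower number from compound 1 to compound 4 (0.37 log units; beyond the scatter), so an ethyl chain on this phenyl ring reads close to a methyl group, though not level with 4-methylphenyl. Nothing given here accounts for these differences.

From the compounds shown here alone, how 2-ethylphenyl or 4-ethylphenyl would compare with 3-ethylphenyl remains open. So does the reading of a phenyl group carrying an amine, a carboxylic acid or a longer chain such as butyl at this position.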